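The compounds below may be only part of what the source reports. "The series", "measured", "known", "first", "only" and "open" are said of these compounds alone.

Compound 1, `CCN(CC)S(=O)(=O)c1ccc(S(=O)(=O)N2CCC[C@@H](C(=O)NC3CN(C(=O)C4CC4)C3)C2)cc1`, gives 18500 nM in a functional assay on BXPC-3 cells (Homo sapiens) for inhibition, read by MTT assay, with a stated time of 7 days; a lower number here means a stronger inhibitor, a higher number a weaker inhibitor.
Compound 2, `CCOC(=O)[C@@H]1CCCN(S(=O)(=O)c2ccc(S(=O)(=O)N3CCCCC3)cc2)C1`, gives 3300 nM in this assay.
Compound 3, `CCOC(=O)[C@@H]1CCCN(S(=O)(=O)c2ccc(S(=O)(=O)N(CC)CC)cn2)C1`, gives 1400 nM in this assay.

Of these three numbers, compound 1 stands at the highest, which in this assay means the weakest inhibition. Compound 2 sits nearest to it, with a lower number that lies beyond the usual scatter of repeated measurements, and compound 3 sits furthest away, with a number lower still. None of these three compounds differs from another in only one place, so the numbers show only where each compound stands, not what any single change does.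

Compound 4, `CCN(CC)S(=O)(=O)c1ccc(S(=O)(=O)N2CCC[C@@H](C(=O)NC3CN(C(=O)NC(C)(C)C)C3)C2)cc1`, differs from compound 1 in one place: (tert-butyl)amino in place of cyclopropyl on a carbonyl carbon. Among the compounds with values here, no measured pair here tells how this assay responds to such a change, so there is no reference step to lean on. The rest of the molecule, including the shared core and the sulfonyl groups, stays the same. The change sits at the far end of the molecule from the core, and nothing in the three measured compounds speaks for or against a large effect from it. The expectation is therefore a step from compound 1 to compound 4 of a 1.2-fold lower number from compound 1 to compound 4 (0.09 log units; within the scatter), in no firm direction and not clearly beyond the scatter. Compound 4 is accordingly estimated at 15000 nM in this assay, within a range from 5000 nM to 45000 nM.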

Compound 4, half-maximal inhibitory concentration: 10100 nM
Compound 4: the middle estimate sits 1.5-fold (0.17 log units) above what was measured; low and high end bracket the measured number.
By their numbers in this assay, from the lowest: compound 3; then compound 2; then compounds 4 and 1 (each within the scatter of the next).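

Within the data shown here, the first step that can be read in this assay is a 1.8-fold lower number from compound 1 to compound 4 (0.26 log units; within the scatter), and it stays within the usual scatter, so compound 1 and compound 4 cannot be told apart by this read-out. On this carbonyl carbon, then, replacing cyclopropyl with (tert-butyl)amino takes away a three-membered ring and brings in a nitrogen and a hydrogen-bond donor, yet the number does not move by more than repeated measurements of one compound might. The change is a large one on paper, but this pair gives no sign that the assay responds to it, and nothing measured alongside these compounds explains why the step is so small.

On these data alone, it remains open whether any group on this carbonyl carbon can move the number beyond the scatter, for example a longer chain such as n-butyl, a phenyl ring, or a group carrying a carboxylic acid or a free amine. A single pair also leaves open whether the same replacement would give an equally small step on a different core, such as one carrying a piperidine sulfonyl group in place of the diethylamino sulfonyl group.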